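A few compounds are considered here, and "the series" means these few. Any claim that something is new, unique, unknown or untested is made for them only; others in the source may bear on it.

Working notes on the series.

The shared core of compound 1 `O=C(O)c1csc([C@H]2CC[C@@H]3[C@@H](COc4ccc(OC(F)(F)F)cc4)[C@H](O)C[C@@H]3O2)n1` carries a substituted phenoxy group; in an assay on HEK293 cells for agonist activity at prostaglandin E2 receptor EP2 subtype (Homo sapiens), read by a beta-galactosidase reporter and beta-arrestin recruitment, with a stated time of 90 min (on this read-out lower numbers stand for an effect already at smaller amounts and higher numbers for an effect only at larger amounts of compound), compound 1 gives 4500 nM. Compound 2 `Cc1ccc(OC[C@@H]2[C@H]3CC[C@H](c4nc(C(=O)O)cs4)O[C@H]3C[C@H]2O)cc1` replaces that group with 4-methylphenyl. In this assay compound 2 reaches only the assay limit of > 10000 nM, not a number, so compound 2 stands at the weak end of what has been measured so far (the limit of > 10000 nM in this assay, at which 1 of the 3 values shown sits). Compound 3 `O=C(O)c1csc([C@H]2CC[C@@H]3[C@@H](COc4cccc(OC(F)(F)F)c4)[C@H](O)C[C@@H]3O2)n1` gives 69 nM in this assay.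

The step from compound 2 to compound 4 `O=C(O)c1csc([C@H]2CC[C@@H]3[C@@H](COc4ccccc4C(F)(F)F)[C@H](O)C[C@@H]3O2)n1` is 2-(trifluoromethyl)phenyl in place of 4-methylphenyl on an oxygen on a saturated carbon. Within the data shown here, the one measured step that bears on it, an at least 2.2-fold higher number from compound 1 to compound 2 (0.34 log units; beyond the scatter), ran in the opposite sense: methyl in place of trifluoromethoxy raised the number. Reversing to a fluorinated group should therefore lower the number, but a 2-(trifluoromethyl)phenyl group has no measured counterpart here, and compound 1 and compound 3 show that where the fluorinated group sits matters greatly. Compound 4 is therefore expected at 1500 nM, within 150 nM to 10000 nM, a step of an at least 6.6-fold lower number from compound 2 to compound 4 (0.82 log units; beyond the scatter) that is uncertain in size.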

Compound 4, half-maximal effective concentration: 11 nM
Compound 4: middle estimate off by 140-fold (2.13 log units), on the high side, and the stated range ends above it.
By their numbers in this assay, from the lowest: compound 4; then compound 3; then compound 1. At a limit, above all of these: compound 2.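

Replacing 4-methylphenyl with 2-(trifluoromethyl)phenyl on an oxygen on a saturated carbon gives an at least 900-fold lower number from compound 2 to compound 4 (2.95 log units; beyond the scatter) in this assay, so this aryl group can move the number much further than an at least 2.2-fold higher number from compound 1 to compound 2 (0.34 log units; beyond the scatter) suggested. A fluorinated group alone does not settle the outcome: compound 1, with its trifluoromethoxy group, gives 4500 nM, whereas compound 4 gives 11 nM. The value of compound 2 is a limit and not a number, so the step has a bound rather than a fixed size: the limit of > 10000 nM in this assay, at which 1 of the 4 values shown sits.

The compounds shown leave open whether the low number of compound 4 depends on the trifluoromethyl group itself or on its place on the phenyl ring. From the compounds shown here alone, how a chlorine or a nitrile in place of that trifluoromethyl group would read in this assay also remains open.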